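Furan for thiophene on two nucleoside cores

The source may hold more compounds than are shown below. What is called first, only, known or untested is meant among the compounds shown, and "the series" means these compounds.

Compound 1 `O=c1[nH]cnc2c1c(-c1ccoc1)cn2[C@@H]1O[C@H](CO)[C@@H](O)[C@H]1O` and compound 2 `O=c1[nH]cnc2c1c(-c1cccs1)cn2[C@@H]1O[C@H](CO)[C@@H](O)[C@H]1O` share one core, while compound 3 `Nc1nc(N)c2c(-c3cccs3)cn([C@@H]3O[C@H](CO)[C@@H](O)[C@H]3O)c2n1` and compound 4 `Nc1nc(N)c2c(-c3ccoc3)cn([C@@H]3O[C@H](CO)[C@@H](O)[C@H]3O)c2n1` share another; how the two cores differ is not broken down here. In a functional assay on HL-60 cells (Homo sapiens) for antiproliferative activity, read by XTT assay, with a stated time of 72 h (on this read-out lower numbers stand for stronger inhibition and higher numbers for weaker inhibition), compound 1 gives 6370 nM. Compound 2 reaches only the limit of this assay, > 20000 nM. Compound 3 likewise reaches only the limit of this assay, > 20000 nM. The change from compound 2 to compound 1 is furan-3-yl in place of thiophen-2-yl on an aromatic carbon, and it made an at least 3.1-fold lower number from compound 2 to compound 1 (0.49 log units; beyond the scatter). The same change, (furan-3-yl in place of thiophen-2-yl on an aromatic carbon), is made from compound 3 to compound 4, at a place described in identical words. The step on the first core is only bounded, because the limit of > 20000 nM in this assay, at which 2 of the 3 values shown sit, caps what is known of compound 2, and compound 3 sits at the same limit. Compound 4 is therefore expected to show an at least 1.6-fold lower number from compound 3 to compound 4 (0.22 log units; that floor lies within the scatter), an estimate that rests on compound 3 at > 20000 nM and on the bounded step of the first core. Compound 4 is estimated at 12000 nM, within 3000 nM to 40000 nM.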

Compound 4, half-maximal inhibitory concentration: > 20000 nM
Compound 4 gave a limit, no number; the forecaster's own chance of this, stated with the estimate: 45%; middle value at least 1.6-fold (0.22 log units) away from the limit.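

In this assay compound 4 gives > 20000 nM, which is a limit and not a number. No step can be read from compound 3 to compound 4, because both compounds rest on a limit: the limit of > 20000 nM in this assay, at which 3 of the 4 values shown sit. From the compounds shown here alone, whether furan-3-yl in place of thiophen-2-yl changes the number at all on the core of compound 3 stays open.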